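This account rests on a few compounds, and the source may have more. Where it says the series, first, only, none or still open, it means among the compounds named here.

Compound 1 `COc1cc(C(=O)c2cn(-c3ccc(C)cc3)cc2-c2ccoc2)cc(OC)c1OC` gives 18 nM
Compound 2 `COc1cc(C(=O)c2cn(-c3ccc(C)cc3)cc2-c2nccs2)cc(OC)c1OC` gives 14 nM
Compound 3 `COc1cc(C(=O)c2cn(-c3ccc(C)cc3)cc2-c2cccnc2)cc(OC)c1OC` gives 19 nM

These values come from a functional assay on MCF7 cells (Homo sapiens) for inhibition, with a stated time of 96 h (a lower number here means a stronger inhibitor, a higher number a weaker inhibitor), and compound 3 sits level with the other two, showing a 1.1-fold higher number from compound 1 to compound 3 (0.02 log units; within the scatter) and a 1.4-fold higher number from compound 2 to compound 3 (0.13 log units; within the scatter). Compound 4 `COc1cc(C(=O)c2cn(-c3ccc(C)cc3)cc2-c2ccncc2)cc(OC)c1OC` has pyridin-4-yl in place of pyridin-3-yl on an aromatic carbon, and the count of the change reads (pyridin-4-yl in place of pyridin-3-yl on an aromatic carbon). As far as these compounds go, this exact swap is untested, so the closest evidence is the swaps already made at this place, which also include a 1.3-fold lower number from compound 1 to compound 2 (0.11 log units; within the scatter). None left the scatter, so no real shift in either direction is expected in this assay. The expected move is a 1.1-fold higher number from compound 3 to compound 4 (0.02 log units; within the scatter). The estimate for compound 4 is 20 nM, expected to fall between 9 nM and 45 nM.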

Compound 4, half-maximal inhibitory concentration: 9 nM
Compound 4: the middle estimate sits 2.2-fold (0.35 log units) above what was measured; low and high end bracket the measured number.
By their numbers in this assay, from the lowest: compounds 4, 2, 1 and 3 (each within the scatter of the next, the first and the last beyond it).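

Swapping pyridin-3-yl for pyridin-4-yl uses the same atoms joined differently, yet it gives the first step at this place to pass the scatter in this assay (a 2.1-fold lower number from compound 3 to compound 4 (0.32 log units; beyond the scatter)). The other two comparisons stay inside the scatter (a 1.6-fold lower number from compound 2 to compound 4 (0.19 log units; within the scatter); a 2.0-fold lower number from compound 1 to compound 4 (0.30 log units; within the scatter)), so compound 4 is separated only from compound 3. Nothing available here accounts for the gap between these two pyridines.

Still open, as far as these compounds go, is how a pyridin-2-yl group would compare, and whether a non-aromatic group here, such as a carboxylic acid or a dimethylamino group, would keep these values.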